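Plasma stability notes: from compound 2 to compound 3

A few compounds are considered here, and "the series" means these few. Any claim that something is new, unique, unknown or untested is made for them only; others in the source may bear on it.

Compound 1 `O=C(NCCCCCCc1ccccc1)Oc1cccc(-c2ccccc2)c1` gives 0.14 h in an ADME assay on a cell-free system (plasma, Rattus norvegicus, strain Wistar) for metabolic stability, read by HPLC, tested at 1 uM; on this read-out lower numbers stand for a shorter-lived compound and higher numbers for a longer-lived compound.
Compound 2 `O=C(NC1CCC1)Oc1cccc(-c2ccccc2)c1` gives 0.332 h in this assay.

Of the two numbers measured, compound 2 stands highest; its nearest neighbour is compound 1, whose number is lower by a gap that lies beyond the usual scatter. Within the data shown here, no pair of measured compounds differs in one place only, so no single step has been characterised yet.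

Compound 3 `CCCCNC(=O)Oc1cccc(-c2ccccc2)c1` has not been measured. It differs from compound 2 by butyl in place of cyclobutyl on an amide-type nitrogen. Nothing measured here separates a ring from an open chain on that nitrogen, so the step in this assay is expected to be small, in no clear direction, and likely within the scatter.

For compound 3 the estimate in this assay is 0.25 h, with a range from 0.1 h to 0.6 h. This estimate implies an expected step of a 1.3-fold lower number from compound 2 to compound 3 (0.12 log units; within the scatter).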

Compound 3, half-life in the plasma assay: 0.36 h
Beside the measured number, compound 3's estimate is 1.4-fold (0.16 log units) below it; the measured number falls inside the stated range.
By their numbers in the plasma assay, from the lowest: compound 1; then compounds 2 and 3 (each within the scatter of the next).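

In the plasma assay, butyl in place of cyclobutyl on an amide-type nitrogen gives a 1.1-fold higher number from compound 2 to compound 3 (0.04 log units; within the scatter), so this read-out does not tell the ring from the open chain at this position. The chain length does register there: in the plasma assay, hydrogen in place of phenethyl on a saturated chain carbon, four bonds along the chain from an amide-type nitrogen, gives a 2.6-fold higher number from compound 1 to compound 3 (0.41 log units; beyond the scatter). The ring-to-chain change itself shows up only in a physicochemical assay, read by HPLC, in phosphate buffer, at pH 7.0 (a higher number here means that more of the compound is left, a lower number that less of the compound is left), where compound 2 gives 22.6% and compound 3 gives 46.7%, a gap beyond the scatter.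

Why the change registers in one read-out and not in the other stays open. So does whether a cyclohexyl group on that nitrogen, or an amine at the end of the butyl chain, would move either number.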